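This account rests on a few compounds, and the source may have more. Where it says the series, first, only, none or still open, it means among the compounds named here.

Within the data shown here, compound 2 `COc1cc2ncnc(Nc3ccc(F)c(Br)c3)c2cc1OCCCCC(=O)Nc1ccc(S(N)(=O)=O)cc1` gives the highest of the two numbers so far in a functional assay on A-431 cells (Homo sapiens) for antiproliferative activity, read by MTT assay, with a stated time of 72 h (on this read-out higher numbers stand for weaker inhibition and lower numbers for stronger inhibition), at 8020 nM, while compound 1 `COc1cc2ncnc(Nc3ccc(F)c(Cl)c3)c2cc1OCCCCC(=O)Nc1ccc(S(N)(=O)=O)cc1` gives 5020 nM; the only measured step, a 1.6-fold higher number from compound 1 to compound 2 (0.20 log units; within the scatter), lies within the scatter. Compound 3 `COc1cc2ncnc(Nc3ccccc3)c2cc1OCCCCC(=O)Nc1ccc(S(N)(=O)=O)cc1` carries a different change: phenyl in place of 3-bromo-4-fluorophenyl on a nitrogen on an aromatic ring. Among the measured compounds shown here, no measured step covers this loss of both halogens, and the one step known, a 1.6-fold higher number from compound 1 to compound 2 (0.20 log units; within the scatter), says only that swapping one halogen for another changes little. A modest rise is therefore expected, with wide uncertainty, as a 1.7-fold higher number from compound 2 to compound 3 (0.24 log units; within the scatter). Compound 3 is estimated at 14000 nM, within a range from 4000 nM to 50000 nM.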

Compound 3, half-maximal inhibitory concentration: 25200 nM
Compound 3: middle estimate off by 1.8-fold (0.26 log units), on the low side, and the stated range covers the measured number.
By their numbers in this assay, from the lowest: compounds 1 and 2 (each within the scatter of the next); then compound 3.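

In this assay, the ring on this nitrogen turns out to matter: phenyl in place of the halogenated rings gives a 3.1-fold higher number from compound 2 to compound 3 (0.50 log units; beyond the scatter) and a 5.0-fold higher number from compound 1 to compound 3 (0.70 log units; beyond the scatter), whereas swapping chloro for bromo stayed within the scatter. Losing both halogens therefore weakens inhibition, though the choice between chloro and bromo cannot be told apart here. No available evidence explains this rise.

Fluoro and the second halogen leave together, so their separate contributions remain open. From the compounds shown here alone, whether a methyl or methoxy group on this ring could replace them also remains open.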